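Removing the Bromo from Compound 3: Expected Cytotoxicity

The compounds below may be only part of what the source reports. "The series", "measured", "known", "first", "only" and "open" are said of these compounds alone.

Measured compounds:
compound 1 `COc1ccc(Cn2cc(/C=N\NC(=O)c3c[nH]c4ccccc34)c3ccccc32)cc1` — 43900 nM
compound 2 `O=C(N/N=C\c1cn(Cc2ccc(Cl)cc2)c2cc(F)ccc12)c1c[nH]c2ccccc12` — 18600 nM
compound 3 `COc1ccc(Cn2cc(/C=N\NC(=O)c3c[nH]c4ccc(Br)cc34)c3ccc(F)cc32)cc1` — 67500 nM

Of the compounds shown here, three sharing one core have been tested in a functional assay on DU-145 cells (Homo sapiens) for cytotoxicity; a lower number here means a stronger inhibitor, a higher number a weaker inhibitor. Compound 3 has the highest number of the three. Its nearest neighbour is compound 1, whose number is lower by an amount that stays within the scatter, so the two cannot be told apart. Compound 2 stands furthest away, with a number lower than that of compound 3 by a gap beyond the scatter.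

The step from compound 3 to compound 4 `COc1ccc(Cn2cc(/C=N\NC(=O)c3c[nH]c4ccccc34)c3ccc(F)cc32)cc1` is a single change: hydrogen in place of bromo on an aromatic carbon. The bromo that sits on the 5-bromo-1H-indol-3-yl part of compound 3 is gone, leaving a plain 1H-indol-3-yl. Compound 4 thus shares with compound 1 the unsubstituted acyl indole and shares with compound 3 the fluoro on the other indole.

Going by the values given here, no measured pair in this set differs in that one place, so the size of the step cannot be read from the data. Because compound 1 gives 43900 nM and compound 3 gives 67500 nM in this assay, the expectation is a step of a 1.5-fold lower number from compound 3 to compound 4 (0.18 log units; within the scatter), within the scatter. Compound 4 is expected to give about 45000 nM, with a range from 20000 nM to 100000 nM.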

Compound 4, half-maximal inhibitory concentration: 16200 nM
For compound 4 the middle estimate is 2.8-fold (0.44 log units) above the measured one; measured number below the stated range.
By their numbers in this assay, from the lowest: compounds 4 and 2 (each within the scatter of the next); then compounds 1 and 3 (each within the scatter of the next).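

Going by these compounds alone, compound 4 gives the only direct reading of this position: in this assay, hydrogen in place of bromo on the aromatic carbon gives a 4.2-fold lower number from compound 3 to compound 4 (0.62 log units; beyond the scatter), a step beyond the scatter, so the bromo on the 5-bromo-1H-indol-3-yl part goes with a weaker result in this pair. Compound 4 also isolates the fluoro, with a 2.7-fold lower number from compound 1 to compound 4 (0.43 log units; beyond the scatter) when fluoro replaces hydrogen on an aromatic carbon; compound 1 and compound 3 differ in two places and could not be told apart, and the two single steps now show that their close numbers conceal opposing changes, one towards a lower number and one towards a higher. Methoxy in place of chloro gives a 1.1-fold lower number from compound 2 to compound 4 (0.06 log units; within the scatter), which stays within the scatter and so shows no readable effect of that exchange.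

Still open, on these data alone, is how an amine or a carboxylic acid in place of the bromo would compare, and whether the bromo step would hold in a compound without the fluoro. Nothing measured here explains the size of the bromo step.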